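Swapping bromo for chloro on a nitropyrrole hydrazide urea

The source may hold more compounds than are shown below. What is called first, only, known or untested is meant among the compounds shown, and "the series" means these compounds.

Of the compounds shown here, two of one shared core have been tested in an ADME assay on Vero cells (Chlorocebus sabaeus) for cytotoxicity, read by MTT assay, with a stated time of 72 h; a higher number here means a weaker inhibitor, a lower number a stronger inhibitor. Compound 1 `Cn1cc([N+](=O)[O-])cc1C(=O)NNC(=O)NC1CCCC1` gives 271000 nM in this assay, and compound 2 `Cn1cc([N+](=O)[O-])cc1C(=O)NNC(=O)Nc1ccc(Br)cc1` gives 602000 nM. Among the measured compounds shown here, compound 2 therefore has the higher of the two numbers, with compound 1 the nearest neighbour, and the one step between them, a 2.2-fold higher number from compound 1 to compound 2 (0.35 log units; beyond the scatter), is modest. Compound 3 `Cn1cc([N+](=O)[O-])cc1C(=O)NNC(=O)Nc1ccc(Cl)cc1` keeps everything in compound 2 except one detail: chloro in place of bromo on an aromatic carbon. For the measured compounds named here, no measured step involves such a halogen swap, so the only available step, a 2.2-fold higher number from compound 1 to compound 2 (0.35 log units; beyond the scatter), concerns a different part of the molecule and does not bear directly on this change. With nothing to point either way, no step beyond the scatter is expected in this assay. Compound 3 is therefore expected to give 600000 nM in this assay, within 300000 nM to 1200000 nM, which means an expected step of a 1.0-fold lower number from compound 2 to compound 3 (0.00 log units; within the scatter).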

Compound 3, half-maximal inhibitory concentration: 290000 nM
Beside the measured number, compound 3's estimate is 2.1-fold (0.32 log units) above it; the measured number lies below the stated range.
By their numbers in this assay, from the lowest: compounds 1 and 3 (each within the scatter of the next); then compound 2.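

In this assay the single halogen atom on the aromatic ring proves to be more than a minor detail: chloro in place of bromo gives a 2.1-fold lower number from compound 2 to compound 3 (0.32 log units; beyond the scatter) and counts as a modest step. The earlier step away from cyclopentyl also reads differently now, since 4-chlorophenyl in place of cyclopentyl gives a 1.1-fold higher number from compound 1 to compound 3 (0.03 log units; within the scatter) and stays within the scatter, so among these three it is compound 2, with its bromo, that stands apart. Nothing available explains why the two halogens differ.

From the compounds shown here alone, two halogens are too few to show a trend, so how a 4-fluorophenyl or a 4-methoxyphenyl group would read at this position remains open. Also open, going by these compounds, is what an amine or a carboxylic acid on that ring would do to the number.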